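The compounds below may be only part of what the source reports. "The series", "measured", "known", "first", "only" and "open" are said of these compounds alone.

In a functional assay on RAW264.7 cells (Mus musculus) for inhibition, read by Griess assay, with a stated time of 24 h (on this read-out higher numbers stand for weaker inhibition and lower numbers for stronger inhibition), compound 1 `O=C(S[C@]12CC[C@@H](O)[C@H]1C(=O)NC2=O)c1ccc(O)cc1` gives 42000 nM and compound 2 `O=C(S[C@@]12CC[C@@H](O)[C@@H]1C(=O)NC2=O)c1ccc(O)cc1` gives 127000 nM, so compound 2 stands highest of the two numbers. Within the data shown here, the single measured step, a 3.0-fold higher number from compound 1 to compound 2 (0.48 log units; beyond the scatter), rests on (the fact that compounds 1 and 2 differ only in the configuration as drawn). Compound 3 `O=C(S[C@]12CC[C@H](O)[C@H]1C(=O)NC2=O)c1ccc(O)cc1` awaits measurement; from compound 2 it differs thus: the two compounds have the same atoms and bonds and differ only in configuration as drawn: 3 of 3 stereo elements differ (all stereocentres are inverted: mirror images); a stereocentre at a saturated ring carbon is drawn S in compound 2 and R in compound 3; a stereocentre at a saturated ring carbon is drawn R in compound 2 and S in compound 3; a stereocentre at a saturated ring carbon is drawn R in compound 2 and S in compound 3. Among the measured compounds shown here, since the change again concerns configuration alone, the step from compound 1 to compound 2 is the only guide, and a modest shift is expected, its direction uncertain. Compound 3 is estimated at 70000 nM in this assay, range 20000 nM to 250000 nM, an expected step of a 1.8-fold lower number from compound 2 to compound 3 (0.26 log units; within the scatter).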

Compound 3, half-maximal inhibitory concentration: 141000 nM
Compound 3: the middle estimate sits 2.0-fold (0.30 log units) below what was measured; measured number inside the range.
By their numbers in this assay, from the lowest: compound 1; then compounds 2 and 3 (each within the scatter of the next).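

Compound 2 and compound 3, a mirror-image pair, are not separated in this assay (a 1.1-fold higher number from compound 2 to compound 3 (0.05 log units; within the scatter)). Inverting the single stereocentre that differs between compound 1 and compound 3 does separate them (a 3.4-fold higher number from compound 1 to compound 3 (0.53 log units; beyond the scatter)). Among the three configurations, only compound 1 stands apart from the other two, with its steps to both beyond the scatter.

From the compounds shown here alone, how the mirror image of compound 1 would read stays open. So does whether an amine or a carboxylic acid in place of a hydroxyl group would shift the number on any of these configurations.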